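From Bromo to Acetyl: Estimating Compound 3

This account rests on a few compounds, and the source may have more. Where it says the series, first, only, none or still open, it means among the compounds named here.

Compound 1 `COc1ccc(NC(=S)Nc2ccc3[nH]ccc3c2)cc1`: 36000 nM
Compound 2 `S=C(Nc1ccc(Br)cc1)Nc1ccc2[nH]ccc2c1`: 5900 nM

In an ADME assay on cells for inhibition of Amine oxidase [flavin-containing] A (Homo sapiens), read by spectrophotometry (a higher number here means a weaker inhibitor, a lower number a stronger inhibitor), compound 2 gives 5900 nM, the lowest of the two numbers measured, while compound 1 gives 36000 nM. Within the data shown here, the only measured step is a 6.1-fold lower number from compound 1 to compound 2 (0.79 log units; beyond the scatter), beyond the scatter and modest in size.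

Compound 3 `CC(=O)c1ccc(NC(=S)Nc2ccc3[nH]ccc3c2)cc1` differs from compound 2 by acetyl in place of bromo on an aromatic carbon. Among the measured compounds shown here, no measured step exchanges a halogen for an acetyl, so that one step informs this change only loosely. Compound 3 is therefore expected near 8000 nM, with a range from 2500 nM to 25000 nM. The expected step is a 1.4-fold higher number from compound 2 to compound 3 (0.13 log units; within the scatter), within the scatter.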

Compound 3, half-maximal inhibitory concentration: 67000 nM
For compound 3 the middle estimate is 8.4-fold (0.92 log units) below the measured one; the whole stated range lies below it.
By their numbers in this assay, from the lowest: compound 2; then compounds 1 and 3 (each within the scatter of the next).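

In this assay, the position para to a large group proves sensitive to the choice of group: acetyl in place of bromo gives a large step (an 11-fold higher number from compound 2 to compound 3 (1.06 log units; beyond the scatter)). Acetyl and methoxy, by contrast, do not separate (a 1.9-fold higher number from compound 1 to compound 3 (0.27 log units; within the scatter)), so among these three groups only bromo stands apart, with compound 2 giving the lowest number. Nothing measured here explains this difference.

The compounds shown leave open whether chloro or fluoro would match bromo, and where an amine or a carboxylic acid would fall at this position.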